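Shifting the chloro group: from compound 2 to compound 3

The source may report more compounds than this note shows. Statements on the series, on what has been measured and on what is new or still open speak of the compounds shown alone.

Measured in a functional assay on PC-3 cells (Homo sapiens) for inhibition, read by sulforhodamine B assay, with a stated time of 48 h; on this read-out lower numbers stand for stronger inhibition of growth and higher numbers for weaker inhibition of growth:
- compound 1 `CC1=CC[C@H](C(C)(C)NC(=S)N/N=C/c2ccccc2)CC1` gives 1300 nM
- compound 2 `CC1=CC[C@H](C(C)(C)NC(=S)N/N=C/c2cccc(Cl)c2)CC1` gives 600 nM

Compound 2 holds the lower of the two numbers. For the measured compounds named here, the only measured step is a 2.2-fold lower number from compound 1 to compound 2 (0.34 log units; beyond the scatter), chloro in place of hydrogen on an aromatic carbon.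

Compound 3 `CC1=CC[C@H](C(C)(C)NC(=S)N/N=C/c2ccc(Cl)cc2)CC1` differs from compound 2 by 4-chlorophenyl in place of 3-chlorophenyl on a carbon with a double bond to nitrogen. Going by the values given here, no measured step moves the chloro substituent from one aromatic position to another; the single step concerns its addition and does not bear on this change. Expected for compound 3 in this assay is therefore no step beyond the scatter. The estimate for compound 3 is 600 nM, range 250 nM to 1500 nM. The expected step is no change at the digits printed from compound 2 to compound 3 (within the scatter).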

Compound 3, concentration for 50% growth inhibition: 50 nM
Estimate against measurement, compound 3: 12-fold (1.08 log units) above, and the stated range ends above it.
By their numbers in this assay, from the lowest: compound 3; then compound 2; then compound 1.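

In this assay, where the chloro group sits counts for more than its presence: 4-chlorophenyl in place of 3-chlorophenyl gives the larger change (a 12-fold lower number from compound 2 to compound 3 (1.08 log units; beyond the scatter)), although both groups hold the same atoms. Chloro in place of hydrogen therefore has no single size of step in this series: the step to the 4-chlorophenyl compound (a 26-fold lower number from compound 1 to compound 3 (1.41 log units; beyond the scatter)) is large, whereas the one to the 3-chlorophenyl compound is modest. No evidence at hand accounts for this difference.

From the compounds shown here alone, whether chloro itself is needed remains open. 4-Methoxyphenyl or 4-aminophenyl in place of 4-chlorophenyl would address that.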